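A few compounds are considered here, and "the series" means these few. Any claim that something is new, unique, unknown or untested is made for them only; others in the source may bear on it.

Three members of this series are in hand: compound 1 `O=C(NCc1ccc(CNS(=O)(=O)c2ccccc2)cc1)c1cccc(F)c1`, compound 2 `O=C(NCc1ccc(CNS(=O)(=O)c2ccccc2)cc1)c1ccc([N+](=O)[O-])cc1` and compound 3 `O=C(NCc1ccc(CNS(=O)(=O)c2ccccc2)cc1)c1ccccc1Cl`. In an assay on MDA-MB-231 cells for binding affinity to C-X-C chemokine receptor type 4 (Homo sapiens), read by immunofluorescence and microscopy, with stated times of 10 min and 30 min (a higher number here means that more compound is needed for the effect, a lower number that less compound is needed), compound 1 gives 100 nM and compound 2 gives 100 nM, whereas compound 3 gives 10 nM, the lowest of the three numbers. For the measured compounds named here, the change between the first two brings no change at the digits printed from compound 1 to compound 2 (within the scatter). Compound 4 `O=C(NCc1ccc(CNS(=O)(=O)c2ccccc2)cc1)c1ccncc1` is the next case: pyridin-4-yl in place of 2-chlorophenyl on a carbonyl carbon. Going by the values given here, no measured step carries a pyridin-4-yl, so the expectation rests only on the observation that the two other groups on this carbonyl both sat higher, namely a 10-fold lower number from compound 1 to compound 3 (1.00 log units; beyond the scatter) and a 10-fold lower number from compound 2 to compound 3 (1.00 log units; beyond the scatter); a return to that level is expected, an upward step of an 8.0-fold higher number from compound 3 to compound 4 (0.90 log units; beyond the scatter) in this assay. The estimate for compound 4 is therefore 80 nM, in a range of 25 nM to 250 nM.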

Compound 4, effective concentration (reported as EC, without a stated level of effect): 10 nM
Beside the measured number, compound 4's estimate is 8.0-fold (0.90 log units) above it; measured number below the stated range.
By their numbers in this assay, from the lowest: compounds 3 and 4 (each within the scatter of the next); then compounds 1 and 2 (each within the scatter of the next).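

In this assay the low level on this carbonyl is not tied to 2-chlorophenyl: pyridin-4-yl, which carries no chlorine, gives no change at the digits printed from compound 3 to compound 4 (within the scatter). The same group gives a 10-fold lower number from compound 2 to compound 4 (1.00 log units; beyond the scatter) and a 10-fold lower number from compound 1 to compound 4 (1.00 log units; beyond the scatter), so two quite different groups now share the low level, while 4-nitrophenyl and 3-fluorophenyl share the higher one. No evidence at hand explains this split. Open, on these data alone, is whether pyridin-3-yl or pyridin-2-yl matches pyridin-4-yl. Also open, as far as these compounds go, is where unsubstituted phenyl, 2-fluorophenyl or an aminophenyl group would fall.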